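This account rests on a few compounds, and the source may have more. Where it says the series, first, only, none or still open, it means among the compounds named here.

Compound 1 `O=C(/C=C/C(=O)N1C/C(=C\c2ccccc2)C(=O)/C(=C/c2ccccc2)C1)Nc1ccc(Cl)c(Cl)c1` gives, in a functional assay on CCRF-CEM cells (Homo sapiens) for cytotoxicity (a higher number here means a weaker inhibitor, a lower number a stronger inhibitor), the lowest of three measured numbers, at 350 nM. Compound 2 `CC(=O)c1ccc(NC(=O)/C=C/C(=O)N2C/C(=C\c3ccc([N+](=O)[O-])cc3)C(=O)/C(=C/c3ccc([N+](=O)[O-])cc3)C2)cc1` gives 360 nM, within the scatter of compound 1, while compound 3 `O=C(/C=C/C(=O)N1C/C(=C\c2ccc([N+](=O)[O-])cc2)C(=O)/C(=C/c2ccc([N+](=O)[O-])cc2)C1)Nc1ccc(Cl)cc1` gives 810 nM, beyond it. For the measured compounds named here, only one measured step alters the aryl group on the amide nitrogen, and that step is a 2.3-fold higher number from compound 2 to compound 3 (0.35 log units; beyond the scatter), a modest shift. Compound 4 `COc1ccc(NC(=O)/C=C/C(=O)N2C/C(=C\c3ccccc3)C(=O)/C(=C/c3ccccc3)C2)cc1` differs from compound 1 by 4-methoxyphenyl in place of 3,4-dichlorophenyl on an amide-type nitrogen. A change of similar size is expected in this assay, without a clear direction, and the estimated step is a 1.4-fold higher number from compound 1 to compound 4 (0.15 log units; within the scatter). Going by the values given here, compound 4 is therefore expected near 500 nM, between 200 nM and 1300 nM, because a 2.3-fold higher number from compound 2 to compound 3 (0.35 log units; beyond the scatter) was the only comparable change and stayed small.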

Compound 4, half-maximal inhibitory concentration: 510 nM
For compound 4 the middle estimate is 1.0-fold (0.01 log units) below the measured one; low and high end bracket the measured number.
By their numbers in this assay, from the lowest: compounds 1, 2, 4 and 3 (each within the scatter of the next, the first and the last beyond it).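

In this assay, 4-methoxyphenyl in place of 3,4-dichlorophenyl on the amide-type nitrogen gives a 1.5-fold higher number from compound 1 to compound 4 (0.16 log units; within the scatter) and so makes no real difference. For the compounds shown here, this is the first look at this position on the core of compound 1, since the earlier step changed the aryl group on a different core. Here, two chlorines can give way to a methoxy group, which adds a hydrogen-bond acceptor, and the number stays within the scatter. Going by these compounds, whether an amine or a carboxylic acid on this phenyl ring would also leave the number unchanged remains open. No measured property is available to explain this result.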